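Lengthening the methyl branch of compound 3

The compounds below may be only part of what the source reports. "The series", "measured", "known", "first", "only" and "open" are said of these compounds alone.

In a functional assay on ES2 cells (Homo sapiens) for inhibition, read by MTT assay, with a stated time of 48 h (on this read-out lower numbers stand for stronger inhibition and higher numbers for weaker inhibition), compound 1 (`O=C(CCCCOc1no[n+]([O-])c1S(=O)(=O)c1ccccc1)NO`) reads 2530 nM and compound 2 (`O=C(COCCOc1no[n+]([O-])c1S(=O)(=O)c1ccccc1)NO`) reads 8690 nM, while compound 3 (`CC(C)(COc1no[n+]([O-])c1S(=O)(=O)c1ccccc1)C(=O)NO`) reads 6880 nM on the same scale. Compound 3 sits in the upper pair of this set. That pair stays unresolved, as a 1.3-fold lower number from compound 2 to compound 3 (0.10 log units; within the scatter) shows. The lowest number stands apart, with a 3.4-fold higher number from compound 1 to compound 2 (0.54 log units; beyond the scatter) and a 2.7-fold higher number from compound 1 to compound 3 (0.43 log units; beyond the scatter) as the two modest gaps.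

Compound 4 (`CCCC(C)(COc1no[n+]([O-])c1S(=O)(=O)c1ccccc1)C(=O)NO`) follows through ethyl in place of hydrogen on a saturated chain carbon, two bonds along the chain from a carbonyl carbon and the same difference, cut one bond further out, reads methyl to propyl. Among the compounds with values here, no measured pair adds carbon to this branch, so the evidence is indirect. Within the data shown here, the nearest measured changes replace the whole chain: a 2.7-fold higher number from compound 1 to compound 3 (0.43 log units; beyond the scatter) is modest and a 1.3-fold lower number from compound 2 to compound 3 (0.10 log units; within the scatter) is no real step, and neither gives a size for this extension. Only a small lowering is therefore expected, with a 1.3-fold lower number from compound 3 to compound 4 (0.10 log units; within the scatter) estimated to stay inside the usual scatter. In this assay compound 4 is estimated at 5500 nM with 2500 nM to 12000 nM as the expected range.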

Compound 4, half-maximal inhibitory concentration: 93300 nM
Compound 4: middle estimate off by 17-fold (1.23 log units), on the low side; the whole stated range lies below it.
By their numbers in this assay, from the lowest: compound 1; then compounds 3 and 2 (each within the scatter of the next); then compound 4.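

Ethyl in place of hydrogen on a saturated chain carbon, two bonds along the chain from a carbonyl carbon, gives the largest step in the series so far: in this assay, a 14-fold higher number from compound 3 to compound 4 (1.13 log units; beyond the scatter). The earlier steps shown here replaced the whole chain and were far smaller, with a 3.4-fold higher number from compound 1 to compound 2 (0.54 log units; beyond the scatter) and a 2.7-fold higher number from compound 1 to compound 3 (0.43 log units; beyond the scatter) both modest and a 1.3-fold lower number from compound 2 to compound 3 (0.10 log units; within the scatter) no real step, so this position responds much more strongly to a small change than those comparisons could show, since the entering ethyl counts only 2 heavy atoms, with no ring, no hydrogen-bond donors or acceptors and no net charge. No measurement on hand accounts for the size of this step.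

A single extension, methyl to propyl, cannot show whether the numbers climb gradually with branch length or jump once a given length is passed, and an ethyl branch in place of the methyl, or a longer chain such as butyl, would separate those two cases. As far as these compounds go, whether a terminal amine or a carboxylic acid on the propyl branch would read like compound 4 or like compound 3 also remains open.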